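A few compounds are considered here, and "the series" means these few. Any claim that something is new, unique, unknown or untested is made for them only; others in the source may bear on it.

The shared core is carried by compound 1 `CC(C)n1c(/C=C2\SC(=O)N(CC(=O)N3CCCC3)C2=O)nc2ccccc21`, compound 2 `Cn1c(/C=C2\SC(=O)N(CC(=O)N3CCOCC3)C2=O)nc2ccccc21` and compound 3 `COc1cc2c(cc1OC)CN(C(=O)CN1C(=O)S/C(=C\c3nc4ccccc4n3C(C)C)C1=O)CC2`, which differ in the amide attached to the exocyclic chain. In a functional assay on PC-3 cells (Homo sapiens) for inhibition, read by MTT assay, with a stated time of 48 h (on this read-out higher numbers stand for weaker inhibition and lower numbers for stronger inhibition), compound 1 gives > 50000 nM, which is a limit of the assay and not a measured number. Compound 2 gives > 50000 nM, again a limit. Compound 3 gives > 50000 nM, also a limit. Every value shown thus sits at the limit of > 50000 nM in this assay, at which 3 of the 3 values shown sit, so compound 1 cannot be ranked against the others: the numbers say only that all three fall outside what the assay resolves. Going by the values given here, no step between measured compounds is known.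

Compound 4 `CC(C)n1c(/C=C2\SC(=O)N(CC(=O)Nc3cc(C(C)(C)C)on3)C2=O)nc2ccccc21` is the next member. Relative to compound 1 the change is (5-(tert-butyl)-1,2-oxazol-3-yl)amino in place of pyrrolidin-1-yl on a carbonyl carbon. Among the compounds with values here, with three limits and no resolved step, the series gives no size or direction for this change. The expectation for compound 4 is therefore set at a number no higher from compound 1 to compound 4 (the limit leaves the size open), no shift beyond the scatter. Compound 4 is expected to give about 50000 nM, within 10000 nM to 200000 nM, and is likely to be reported again as a limit.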

Compound 4, half-maximal inhibitory concentration: > 50000 nM
Compound 4: no number, only a limit (the forecaster's own chance of this, stated with the estimate: 70%); the middle value sits exactly at the limit.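

In this assay compound 4 gives > 50000 nM, a limit of the assay. No step can be read between compound 1 and compound 4: the limit of > 50000 nM in this assay, at which 4 of the 4 values shown sit.

The compounds shown leave open whether any change of the amide on the shared core shifts inhibition in this assay.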